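Ester-side alkyl variation and microsomal stability in the series

The source may report more compounds than this note shows. Statements on the series, on what has been measured and on what is new or still open speak of the compounds shown alone.

Working notes on the shared core carried by compound 1 `CCCCc1nc(C(C)C)c(CC(=O)OCC(F)(F)F)c(=O)n1Cc1ccc(-c2ccccc2-c2noc(=O)[nH]2)cc1`, compound 2 `CCCCc1nc(C(C)C)c(CC(=O)OCCC)c(=O)n1Cc1ccc(-c2ccccc2-c2noc(=O)[nH]2)cc1` and compound 3 `CCCCc1nc(C(C)C)c(CC(=O)OC2CCCCC2)c(=O)n1Cc1ccc(-c2ccccc2-c2noc(=O)[nH]2)cc1`. In an ADME assay on microsomes from liver (Homo sapiens) for metabolic stability, with a stated time of 30 min (a higher number here means that more of the compound is left, a lower number that less of the compound is left), compound 1 has no result reported, its entry reading "not determined" (no result reported). In this assay compound 2 gives 7.2% and compound 3 gives 13.3%. Going by the values given here, compound 3 stands highest of the two numbers available, but the single step with a number, a number 6.1 percentage points higher from compound 2 to compound 3 (within the scatter), is within the scatter, so the two values are to be read as alike. Compound 1 stands apart without a number.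

Compound 4 `CCCCc1nc(C(C)C)c(CC(=O)OC(CC)CC)c(=O)n1Cc1ccc(-c2ccccc2-c2noc(=O)[nH]2)cc1` differs from compound 3 by pentan-3-yl in place of cyclohexyl on an oxygen next to a carbonyl group. Among the compounds with values here, the only measured step that bears on this change is the step from compound 2 to compound 3, which altered the same alkyl group on an oxygen next to a carbonyl group and stayed within the scatter. On that basis no step beyond the scatter is expected from compound 3 to compound 4, and the expected step is a number 2.3 percentage points lower from compound 3 to compound 4 (within the scatter). Within the data shown here, for compound 4 in this assay the estimated value is 11%, with a range from 3% to 25%, the range wide because a single within-scatter step is the only guide.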

Compound 4, percent of the compound remaining: 7.7%
Beside the measured number, compound 4's estimate is 3.3 percentage points above it, and the stated range covers the measured number.
By their numbers in this assay, from the lowest: compounds 2, 4 and 3 (each within the scatter of the next).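

In this assay, the step of a number 5.6 percentage points lower from compound 3 to compound 4 (within the scatter) shows that pentan-3-yl in place of cyclohexyl, an open chain for the six-membered carbon ring, stays within the scatter, so this ring is not needed to hold the value at this place. The step of a number 0.5 percentage points higher from compound 2 to compound 4 (within the scatter) adds that ethyl in place of hydrogen on the saturated chain carbon bound to the oxygen also stays within the scatter, which makes compound 2, compound 3 and compound 4 read as alike, with all three values low on this scale and no order among them. No measurement at hand explains why these alkyl groups read alike.

What the compounds shown leave open is whether any group on an oxygen next to a carbonyl group can move the number beyond the scatter, since the three numbers cover only saturated carbon groups and the entry for compound 1 carries no number. A tert-butyl group, a longer chain ending in an amine or a chain ending in a carboxylic acid would test that question at this place.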